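Thiophene group change from compound 3 to compound 4

A few compounds are considered here, and "the series" means these few. Any claim that something is new, unique, unknown or untested is made for them only; others in the source may bear on it.

- compound 1 `Cc1cc(-c2nc3sc(C)cn3c2/C=N/NC(=N)N)c(C)s1` gives 7410 nM in the series
- compound 2 `Cc1cn2c(/C=N/NC(=N)N)c(-c3ccsc3)nc2s1` gives 8130 nM in the series
- compound 3 `N=C(N)N/N=C/c1c(-c2cc(Cl)sc2Cl)nc2n1CCS2` gives 10000 nM in the series

In a functional assay on cells (Melanoma cell, Homo sapiens) for inhibition (a higher number here means a weaker inhibitor of growth, a lower number a stronger inhibitor of growth), compound 3 gives 10000 nM and lies within the scatter of both compound 1 and compound 2, so the three measured values do not separate. Compound 4 `N=C(N)N/N=C/c1c(-c2cccs2)nc2n1CCS2` differs from compound 3 by thiophen-2-yl in place of 2,5-dichlorothiophen-3-yl on an aromatic carbon in this way: thiophen-2-yl in place of 2,5-dichlorothiophen-3-yl on an aromatic carbon. Among the measured compounds shown here, the only measured step that bears on this is a 1.1-fold higher number from compound 1 to compound 2 (0.04 log units; within the scatter) on the core of compound 1, also a change confined to the thiophene group. For the measured compounds named here, no measured step covers the loss of chlorine or a thiophen-2-yl group on the core of compound 3, so the support is thin. No step beyond the scatter is expected in this assay for this change. The estimated change is a 1.2-fold lower number from compound 3 to compound 4 (0.07 log units; within the scatter) and stays small. Compound 4 is expected at 8500 nM with an estimated range from 4000 nM to 18000 nM as the likely span.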

Compound 4, concentration for 50% growth inhibition: 21400 nM
For compound 4 the middle estimate is 2.5-fold (0.40 log units) below the measured one; the measured number lies above the stated range.
By their numbers in this assay, from the lowest: compounds 1, 2 and 3 (each within the scatter of the next); then compound 4.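

In this assay, thiophen-2-yl in place of 2,5-dichlorothiophen-3-yl on the shared core gives a 2.1-fold higher number from compound 3 to compound 4 (0.33 log units; beyond the scatter), so the thiophene group at this position can shift growth inhibition beyond the scatter. Among the compounds shown here, the only earlier step, a 1.1-fold higher number from compound 1 to compound 2 (0.04 log units; within the scatter), showed no such shift, but it lay on the core of compound 1, and the present change removes both chlorine atoms and moves the thiophene attachment at once, so the step cannot be divided between those two parts. No available data explain the size of this step.

As far as these compounds go, it remains open whether unsubstituted thiophen-3-yl on the core of compound 3 would read closer to compound 3 or compound 4. Also open, from the compounds shown here alone, is how this position responds to a group outside the thiophenes, such as a phenyl ring or an amine.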